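The source may report more compounds than this note shows. Statements on the series, on what has been measured and on what is new or still open speak of the compounds shown alone.

Measured compounds:
compound 1, `Cc1nc(CN2CCN(c3cccc4[nH]c(-c5ccc(C(C)(C)C)cc5)nc34)CC2)c[nH]1`, giving 7.5 nM in an assay on isolated protein for displacement of a labelled ligand from Gonadotropin-releasing hormone receptor (Homo sapiens); on this read-out higher numbers stand for weaker inhibition and lower numbers for stronger inhibition
compound 2, `CCCCn1cnc(CN2CCN(c3cccc4[nH]c(-c5ccc(C(C)(C)C)cc5)nc34)CC2)c1C`, giving 46 nM in this assay

Among the measured compounds shown here, compound 2 stands at the higher of the two numbers seen so far; the only measured step, a 6.1-fold higher number from compound 1 to compound 2 (0.79 log units; beyond the scatter), is modest but lies beyond the scatter. Compound 3, `CCCn1cc(CN2CCN(c3cccc4[nH]c(-c5ccc(C(C)(C)C)cc5)nc34)CC2)nc1C`, has not been measured; it differs from compound 2 by 2-methyl-1-propyl-1H-imidazol-4-yl in place of 1-butyl-5-methyl-1H-imidazol-4-yl on a saturated chain carbon bound to an amine nitrogen in a ring. For the measured compounds named here, the sole step that bears on this change is the one from compound 1 to compound 2, and that step altered the imidazole in two respects at once, so its size cannot be split between the alkyl on the ring nitrogen and the methyl. Compound 3 carries the 2-methyl that compound 1 also carries, while keeping an alkyl chain on the ring nitrogen as compound 2 does, so a number between those two is the natural expectation. The step is expected to be a decrease, a 2.3-fold lower number from compound 2 to compound 3 (0.36 log units; beyond the scatter), smaller than the measured one and close to the edge of the scatter. Compound 3 is therefore expected at 20 nM, with a range from 7 nM to 60 nM.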

Compound 3, half-maximal inhibitory concentration in the Gonadotropin-releasing hormone receptor assay: 18 nM
Beside the measured number, compound 3's estimate is 1.1-fold (0.05 log units) above it; the range from low to high includes it.
By their numbers in the Gonadotropin-releasing hormone receptor assay, from the lowest: compound 1; then compound 3; then compound 2.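

In the Gonadotropin-releasing hormone receptor assay, the propyl group is the only difference in a 2.4-fold higher number from compound 1 to compound 3 (0.38 log units; beyond the scatter), with propyl in place of hydrogen on an aromatic nitrogen, so this step gives a single-change reading that the earlier step, which altered the imidazole in two respects at once, could not give. a 2.6-fold lower number from compound 2 to compound 3 (0.41 log units; beyond the scatter) then shows that 2-methyl-1-propyl-1H-imidazol-4-yl is preferred over 1-butyl-5-methyl-1H-imidazol-4-yl at this place, on a saturated chain carbon bound to an amine nitrogen in a ring, although the contributions of chain length and methyl placement remain combined in this change. The same change also separates the two compounds much more widely in a physicochemical assay for solubility, at pH 7.4 (a higher number here means a more soluble compound, a lower number a less soluble compound), where compound 2 gives 3 ug/mL and compound 3 gives 55 ug/mL, and the step is large: the measured solubility of compound 2, 3 ug/mL, and of compound 3, 55 ug/mL, an 18-fold higher number (1.26 log units; beyond the scatter)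

The compounds shown do not settle whether the methyl placement or the shorter chain drives either shift, a question that the 1-butyl chain paired with the 2-methyl group, or the 1-propyl chain paired with the 5-methyl group, would address directly. They also leave open whether an ethyl chain, or a chain ending in a hydroxyl group or an amine, on the aromatic nitrogen would bring the number closer to that of compound 1.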